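The source may report more compounds than this note shows. Statements on the series, on what has been measured and on what is new or still open speak of the compounds shown alone.

The measured compounds:
compound 1, `Cc1ccc(S/C(=C/c2ccc(N(C)C)cc2)C(=O)c2ccc(Cl)cc2)cc1`: > 100000 nM
compound 2, `COc1ccc(/C=C(/Sc2ccc(C)cc2)C(=O)c2ccc(Cl)cc2)cc1O`: 1000 nM

Both were tested in a functional assay on DU-145 cells (Homo sapiens) for inhibition, read by trypan blue exclusion, with a stated time of 96 h; a higher number here means a weaker inhibitor of growth, a lower number a stronger inhibitor of growth. For compound 1 the value > 100000 nM is a limit of the assay and not a number (the limit of > 100000 nM in this assay, at which 1 of the 2 values shown sits). Compound 2 gives 1000 nM. Within the data shown here, the one measured step, an at least 100-fold lower number from compound 1 to compound 2 (2.00 log units; beyond the scatter), changes the aryl group on the double-bonded chain carbon and leaves the group on the sulfur untouched.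

Compound 3, `CN(C)c1ccc(/C=C(/SCc2ccc(F)cc2)C(=O)c2ccc(Cl)cc2)cc1`, differs from compound 1 in a different place: 4-fluorobenzyl in place of 4-methylphenyl on a sulfur. Among the measured compounds shown here, no measured step changes the group on the sulfur, so the measured pair gives no direct guide to the size or direction of this change. Compound 3 keeps the 4-(dimethylamino)phenyl of compound 1, and compound 1 sits at the limit (the limit of > 100000 nM in this assay, at which 1 of the 2 values shown sits); that is the only anchor available. The step is expected to be an at least 1.2-fold lower number from compound 1 to compound 3 (0.09 log units; that floor lies within the scatter). Compound 3 is therefore expected to give about 80000 nM, within a range from 10000 nM to 300000 nM, with a real chance that only a limit is again reported.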

Compound 3, concentration for 50% growth inhibition: 50000 nM
The estimate for compound 3 lay 1.6-fold (0.20 log units) above the measured number, within the range that was stated.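

In this assay compound 3, which carries 4-fluorobenzyl in place of 4-methylphenyl on the sulfur, gives 50000 nM, a measured number with the 4-(dimethylamino)phenyl group still in place. For compound 1 the value > 100000 nM is a limit of the assay and not a number, and it is the only such value among the compounds shown: the limit of > 100000 nM in this assay, at which 1 of the 3 values shown sits. The step can therefore be read only as a floor, an at least 2.0-fold lower number from compound 1 to compound 3 (0.30 log units; that floor lies within the scatter), so the change on the sulfur has a lower bound on its size but no measured size, and it cannot be said to go beyond the scatter.

Among these compounds, what remains open is how 4-fluorobenzyl on the sulfur behaves alongside the 3-hydroxy-4-methoxyphenyl group of compound 2, since the one step seen on the sulfur was read with 4-(dimethylamino)phenyl in place. From the compounds shown here alone, it is also open whether the fluorine or the extra chain carbon matters more, a question that plain benzyl or a longer chain such as 2-phenylethyl on the sulfur would address.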